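This account rests on a few compounds, and the source may have more. Where it says the series, first, only, none or still open, it means among the compounds named here.

Measured compounds:
- compound 1, `Cc1ccccc1C(=O)N(Cc1ccco1)Cc1cc2cccc(C)c2[nH]c1=O`: in an ADME assay on MT2 cells (Homo sapiens) for cytotoxicity, read by XTT assay, with a stated time of 4 days (a lower number here means that less compound is tolerated, a higher number that more compound is tolerated), compound 1 gives > 64700 nM, which is a limit of the assay and not a number.
- compound 2, `Cc1ccc2[nH]c(=O)c(CN(Cc3ccco3)C(=O)c3ccccc3)cc2c1`: in this assay compound 2 gives > 67100 nM, again a limit of the assay and not a number.

Compound 2 thus stands at the limit (the limit of > 67100 nM in this assay, at which 1 of the 2 values shown sits). Compound 1 sits at the limit (the limit of > 64700 nM in this assay, at which 1 of the 2 values shown sits). For the measured compounds named here, since neither value is a number, no step between the two measured compounds can be counted, and the two values together show only that both compounds are tolerated up to the limits reached.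

Compound 3, `Cc1ccc2[nH]c(=O)c(CN(Cc3ccco3)C(=O)c3ccc(F)c(F)c3)cc2c1`, is not yet measured in this assay. Its change from compound 2 is 3,4-difluorophenyl in place of phenyl on a carbonyl carbon, on the carbonyl carbon whose other neighbours are an amide-type nitrogen; cut one bond further out, benzoyl becomes (3,4-difluorophenyl)carbonyl. Going by the values given here, with no measured step available and both values being limits, the data give no direction for this change; the expectation is that compound 3 again reaches the limit of this assay, with no step beyond the scatter. Compound 3 is expected to give 67100 nM in this assay, within 30000 nM to 120000 nM. The step expected is a number no higher from compound 2 to compound 3 (the limit leaves the size open), which is estimated as essentially no change.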

Compound 3, half-maximal cytotoxic concentration: > 24500 nM
Compound 3 gave a limit, no number; the forecaster's own chance of this, stated with the estimate: 80%; the middle value does not contradict the limit.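

In this assay, compound 2 and compound 3 both give limits of the assay and not numbers, and no step can be read between them. Still open, from the compounds shown here alone, is where the half-maximal cytotoxic concentration of compound 1, compound 2 or compound 3 lies, and whether 3,4-difluorophenyl in place of phenyl on a carbonyl carbon changes it.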